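This account rests on a few compounds, and the source may have more. Where it says the series, first, only, none or still open, it means among the compounds named here.

Of the compounds shown here, three with a shared core have been measured in an assay for inhibition of Thromboxane-A synthase (Homo sapiens), using microsomes; on this read-out higher numbers stand for weaker inhibition and lower numbers for stronger inhibition. Compound 1 `O=C(O)CC/C=C\CC1COC(c2ccc(Cl)cc2Cl)OC1c1cccnc1` gives 42 nM, compound 2 `O=C(O)CC/C=C\CC1COC(c2cccc3ccccc23)OC1c1cccnc1` gives 40 nM, and compound 3 `Cc1ccc(C#N)c(OC(C)(C)C2OCC(C/C=C\CCC(=O)O)C(c3cccnc3)O2)c1` gives 50 nM, the highest of the three numbers, though its gaps to compound 1 and compound 2 both lie within the scatter. Compound 4 `CC(C)(Oc1ccccc1F)C1OCC(C/C=C\CCC(=O)O)C(c2cccnc2)O1` carries 2-fluorophenyl in place of 2-cyano-5-methylphenyl on an oxygen on a saturated carbon. For the measured compounds named here, the only measured step, a 1.1-fold lower number from compound 1 to compound 2 (0.02 log units; within the scatter), exchanges an aryl group on a saturated ring carbon, a different place from the oxygen-borne change here, so it bears on compound 4 only loosely; it suggests that aryl swaps on this core leave this assay unmoved. No step beyond the scatter is therefore expected, and compound 4 is estimated at 50 nM (range 20 nM to 125 nM), an expected step of no change at the digits printed from compound 3 to compound 4 (within the scatter).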

Compound 4, half-maximal inhibitory concentration: 45 nM
Compound 4: middle estimate off by 1.1-fold (0.05 log units), on the high side; measured number inside the range.
By their numbers in this assay, from the lowest: compounds 2, 1, 4 and 3 (each within the scatter of the next).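

In this assay, the change on an oxygen on a saturated carbon gives a 1.1-fold lower number from compound 3 to compound 4 (0.05 log units; within the scatter), the first step read at this position. The nitrile and methyl of 2-cyano-5-methylphenyl leave and a fluorine enters on the phenyl ring, yet the step stays within the scatter, so this exchange shows no measurable effect on the read-out. Nothing on hand accounts for this result. The compounds shown leave open whether an amine or a carboxylic acid on this aryl ring would shift the number. They also leave open whether a longer alkyl chain in place of the aryl group would do so.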